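The source may report more compounds than this note shows. Statements on the series, on what has been measured and on what is new or still open speak of the compounds shown alone.

Three compounds share one core and differ only in the aromatic group attached to it, which makes the effect of that group the question here. Compound 1, `O=C(NO)c1ccc(NCc2nc(-c3cccc(Cl)c3)nn2-c2ccccc2)cc1`, gives 115 nM in an assay on Sf9 cells for inhibition of protein deacetylase HDAC6 (Homo sapiens), read by fluorescence, with a stated time of 40 min; a lower number here means a stronger inhibitor, a higher number a weaker inhibitor. Compound 2, `O=C(NO)c1ccc(NCc2nc(-c3ccc(Cl)cc3)nn2-c2ccccc2)cc1`, gives 181 nM in this assay, and the step of a 1.6-fold higher number from compound 1 to compound 2 (0.20 log units; within the scatter) is small. Compound 3, `O=C(NO)c1ccc(NCc2nc(-c3cc4ccccc4s3)nn2-c2ccccc2)cc1`, gives 324 nM in this assay. The step of a 2.8-fold higher number from compound 1 to compound 3 (0.45 log units; beyond the scatter) is the only one among the three that lies beyond the scatter, while the step of a 1.8-fold higher number from compound 2 to compound 3 (0.25 log units; within the scatter) stays within it, so compound 3 is clearly apart from compound 1 but not from compound 2.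

Compound 4, `Cc1ccsc1-c1nc(CNc2ccc(C(=O)NO)cc2)n(-c2ccccc2)n1`, has not yet been measured. It changes compound 3 by 3-methylthiophen-2-yl in place of 1-benzothiophen-2-yl on an aromatic carbon. All three measured steps concern exactly this position, and none of them moved the number by more than a modest amount, so the new group is unlikely to change the picture sharply. On that basis compound 4 is expected to show a 1.3-fold lower number from compound 3 to compound 4 (0.11 log units; within the scatter), a shift that may well stay inside the scatter. The estimate for compound 4 in this assay is 250 nM, with a range from 120 nM to 520 nM.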

Compound 4, half-maximal inhibitory concentration: 30.7 nM
Compound 4: the middle estimate sits 8.1-fold (0.91 log units) above what was measured, and the stated range ends above it.
By their numbers in this assay, from the lowest: compound 4; then compounds 1, 2 and 3 (each within the scatter of the next, the first and the last beyond it).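

The position is far less forgiving than the first three compounds suggested: in this assay, swapping 1-benzothiophen-2-yl for the smaller 3-methylthiophen-2-yl gives the largest change so far (an 11-fold lower number from compound 3 to compound 4 (1.02 log units; beyond the scatter)). The new group also stands clear of both chlorophenyl compounds (a 5.9-fold lower number from compound 2 to compound 4 (0.77 log units; beyond the scatter); a 3.7-fold lower number from compound 1 to compound 4 (0.57 log units; beyond the scatter)), which makes compound 4 the strongest inhibitor of the four, since all of its steps lie beyond the scatter. Compound 3 and compound 4 both carry a five-membered aromatic ring with one hetero atom at this position, yet compound 3 has the highest number of the four, so that ring alone does not go with strong inhibition here.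

Nothing available explains why this group gives so much lower a number. On these data alone, it also remains open whether the methyl, the single thiophene ring or the two together matter, which a comparison with plain thiophen-2-yl and 2-methylphenyl could separate, and how an amine or a carboxylic acid in place of that methyl would behave.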